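The source may report more compounds than this note shows. Statements on the series, on what has been measured and on what is new or still open speak of the compounds shown alone.

Measured in a functional assay on MCF7 cells (Homo sapiens) for cytotoxicity, read by MTT assay, with a stated time of 48 h; a lower number here means a stronger inhibitor, a higher number a weaker inhibitor:
Compound 1 `Cc1ncc([N+](=O)[O-])n1CCSc1nnc(-c2ccc(N)cc2)o1`: 19800 nM
Compound 2 `Cc1ncc([N+](=O)[O-])n1CCSc1nnc(-c2ccccc2F)o1`: 20500 nM
Compound 3 `Cc1ncc([N+](=O)[O-])n1CCSc1nnc(-c2ccc(F)cc2)o1`: 8100 nM

Of these, compound 3 has the lowest number, and it is separated from both others: the data show a 2.4-fold lower number from compound 1 to compound 3 (0.39 log units; beyond the scatter) and a 2.5-fold lower number from compound 2 to compound 3 (0.40 log units; beyond the scatter), each modest. The remaining pair shows a 1.0-fold higher number from compound 1 to compound 2 (0.02 log units; within the scatter), within the scatter.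

The next compound, compound 4 `Cc1ncc([N+](=O)[O-])n1CCSc1nnc(-c2cccs2)o1`, keeps the shared core and carries thiophen-2-yl in place of 4-fluorophenyl on an aromatic carbon. For the measured compounds named here, none of the measured steps replaces the six-membered ring itself, so they bear on this change only indirectly, and no thiophen-2-yl compound has yet been measured here.

Across the three measured compounds, changing this group gave a modest step or none. The 4-fluorophenyl of compound 3 goes with the lowest number, 8100 nM, so a small move to a higher number is expected in this assay, not clearly beyond the scatter. The expected step is a 1.5-fold higher number from compound 3 to compound 4 (0.17 log units; within the scatter). For compound 4 the estimated value is 12000 nM, with an expected range of 5500 nM to 26000 nM.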

Compound 4, half-maximal inhibitory concentration: 25800 nM
Compound 4: the middle estimate sits 2.2-fold (0.33 log units) below what was measured, within the range that was stated.
By their numbers in this assay, from the lowest: compound 3; then compounds 1, 2 and 4 (each within the scatter of the next).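

In this assay, for the compounds shown here, the first step that replaces the six-membered ring itself at this position gives a 3.2-fold higher number from compound 3 to compound 4 (0.50 log units; beyond the scatter) and so takes the smaller thiophen-2-yl ring out of the low range held by the 4-fluorophenyl group. Against the other two aryl groups the picture differs, with a 1.3-fold higher number from compound 2 to compound 4 (0.10 log units; within the scatter) for the change from 2-fluorophenyl and a 1.3-fold higher number from compound 1 to compound 4 (0.11 log units; within the scatter) for the change from 4-aminophenyl, so compound 4 falls together with compounds 1 and 2 and only compound 3 stands apart among the four. Nothing measured here gives a reason for this separation.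

The compounds shown leave open whether the standing of compound 3 depends on fluoro specifically, which 4-chlorophenyl or 4-methoxyphenyl would test on the same shared core, or on a six-membered ring carrying a group at that place more generally. They also leave open whether thiophen-2-yl speaks for five-membered rings as a class, a question that furan-2-yl or thiophen-3-yl at the same aromatic carbon would address.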